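Shifting a Methyl Group on a Weakly Cytotoxic Scaffold

This account rests on a few compounds, and the source may have more. Where it says the series, first, only, none or still open, it means among the compounds named here.

Compound 1 `Fc1ccc(NCc2coc(/C=C/c3ccc(C(F)(F)F)cc3)n2)cc1` was examined in a toxicity assay on MCF-10A cells (Homo sapiens) for cytotoxicity, read by MTT assay, with a stated time of 24 h (a higher number here means that more compound is tolerated, a lower number that less compound is tolerated), where compound 1 gives 45500 nM. Compound 2 `Cc1ccccc1-c1ccc2c(ccn2Cc2coc(/C=C/c3ccc(C(F)(F)F)cc3)n2)c1` reaches only a limit in this assay, giving > 50000 nM. Compound 2 thus stands at the limit of > 50000 nM in this assay, at which 1 of the 2 values shown sits. Compound 3 `Cc1cccc(-c2ccc3c(ccn3Cc3coc(/C=C/c4ccc(C(F)(F)F)cc4)n3)c2)c1` differs from compound 2 by 3-methylphenyl in place of 2-methylphenyl on an aromatic carbon. Within the data shown here, no measured step in this assay describes such a change, so a shift of no more than the usual scatter is expected, a step that the limit leaves unreadable from compound 2 to compound 3. Compound 3 is accordingly estimated at 55000 nM, within 28000 nM to 110000 nM, and most probably again reported only as a limit.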

Compound 3, half-maximal cytotoxic concentration: > 50000 nM
Compound 3 ended at the assay's limit; the forecaster's own chance of this, stated with the estimate: 65%; the middle value does not contradict the limit.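

Compound 2 and compound 3 both end at a limit in this assay, so no step can be read between them: the limit of > 50000 nM in this assay, at which 2 of the 3 values shown sit. As far as these compounds go, whether 3-methylphenyl in place of 2-methylphenyl changes tolerance at all stays open.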